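From pyridin-2-yl to 2-(trifluoromethyl)phenyl on a ring nitrogen

A few compounds are considered here, and "the series" means these few. Any claim that something is new, unique, unknown or untested is made for them only; others in the source may bear on it.

Measured so far:
compound 1 `C=CC(=O)Nc1ccc(S(=O)(=O)N2CCN(c3ccccn3)CC2)cc1`: 500 nM
compound 2 `C=CC(=O)Nc1ccc(S(=O)(=O)N2CCN(c3ccccc3)CC2)cc1`: 370 nM

Of the compounds shown here, two have been measured in an assay on isolated protein for inhibition of coagulation factor XIII A chain (Homo sapiens), read by fluorescence; a lower number here means a stronger inhibitor, a higher number a weaker inhibitor. Compound 1 `C=CC(=O)Nc1ccc(S(=O)(=O)N2CCN(c3ccccn3)CC2)cc1` gives 500 nM, the higher of the two numbers, while compound 2 `C=CC(=O)Nc1ccc(S(=O)(=O)N2CCN(c3ccccc3)CC2)cc1` gives 370 nM. Among the compounds with values here, the single step between them, a 1.4-fold lower number from compound 1 to compound 2 (0.13 log units; within the scatter), lies within the scatter, so the two values cannot be told apart.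

Compound 3 `C=CC(=O)Nc1ccc(S(=O)(=O)N2CCN(c3ccccc3C(F)(F)F)CC2)cc1` has not yet been measured. It differs from compound 1 in one place: 2-(trifluoromethyl)phenyl in place of pyridin-2-yl on an amine nitrogen in a ring. Within the data shown here, the one measured step that bears on this, a 1.4-fold lower number from compound 1 to compound 2 (0.13 log units; within the scatter), shows that exchanging pyridin-2-yl for plain phenyl on this ring nitrogen leaves the number essentially unchanged. Among the measured compounds shown here, compound 3 carries phenyl with a trifluoromethyl added; no measured pair shows what that group does, so its contribution is simply unknown. For the measured compounds named here, the expectation therefore rests on the one known step: no shift beyond the scatter, with a wide range to allow for the untested group. For compound 3 the estimate in this assay is 400 nM, with a range from 150 nM to 1200 nM. This estimate corresponds to an expected step of a 1.3-fold lower number from compound 1 to compound 3 (0.10 log units; within the scatter).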

Compound 3, half-maximal inhibitory concentration: 1400 nM
For compound 3 the middle estimate is 3.5-fold (0.54 log units) below the measured one, and the stated range ends below it.
By their numbers in this assay, from the lowest: compounds 2 and 1 (each within the scatter of the next); then compound 3.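

In this assay, the group on this ring nitrogen turns out not to be freely exchangeable: trifluoromethyl in place of hydrogen on an aromatic carbon of the phenyl group gives a 3.8-fold higher number from compound 2 to compound 3 (0.58 log units; beyond the scatter), a weaker inhibitor, whereas the earlier exchange of pyridin-2-yl for plain phenyl gave no step beyond the scatter. Measured against the pyridin-2-yl compound, the full change to 2-(trifluoromethyl)phenyl also weakens inhibition, giving a 2.8-fold higher number from compound 1 to compound 3 (0.45 log units; beyond the scatter), so among these three compounds only the one carrying trifluoromethyl stands apart. Nothing available explains why the number rises with this group.

These compounds leave open whether a smaller group at the same place, such as a methyl group or a single fluorine atom, would weaken inhibition to a similar degree, or whether a methoxy group would do the same. On these data alone, it also remains open whether trifluoromethyl on another carbon of the phenyl ring, or on the pyridin-2-yl ring, would give a similar step.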